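Removing the chloro from compound 1

This account rests on a few compounds, and the source may have more. Where it says the series, first, only, none or still open, it means among the compounds named here.

Of the compounds shown here, three have been measured in an assay on HEK293 cells for displacement of a labelled ligand from 5-hydroxytryptamine receptor 6 (Homo sapiens); a higher number here means a weaker inhibitor, a lower number a stronger inhibitor. Compound 1 `O=[N+]([O-])c1ccc(N2CCNCC2)cc1NCCOc1ccc(Cl)cc1` gives 290 nM, the lowest number of the three. Compound 2 `CN1CCN(c2ccc(OCc3ccccc3)c(NCc3ccco3)c2)CC1` gives 402 nM, and this lies within the scatter of compound 1, so the two cannot be told apart. Compound 3 `CN1CCN(c2ccc(OCc3ccccc3)c(NCc3ccccc3)c2)CC1` gives 928 nM, beyond the scatter from compound 1. For the measured compounds named here, the only single-point step among the measured compounds is a 2.3-fold higher number from compound 2 to compound 3 (0.36 log units; beyond the scatter).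

Compound 4 `O=[N+]([O-])c1ccc(N2CCNCC2)cc1NCCOc1ccccc1` has not yet been measured in this assay. It differs from compound 1 in one place: hydrogen in place of chloro on an aromatic carbon, on an aromatic carbon of a six-membered aromatic ring of carbon only, para to a large group. Going by the values given here, no measured step tests this kind of change, since the step from compound 2 to compound 3 swaps one ring for another on a saturated chain carbon bound to a nitrogen on an aromatic ring, and was itself only modest. Without a direct precedent, the expectation is a small shift, most likely toward a higher number, with a 1.7-fold higher number from compound 1 to compound 4 (0.22 log units; within the scatter) as the estimated step. Compound 4 is therefore expected to give about 480 nM in this assay, within a range from 200 nM to 1200 nM.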

Compound 4, inhibition constant: 114 nM
The estimate for compound 4 lay 4.2-fold (0.62 log units) above the measured number; measured number below the stated range.
By their numbers in this assay, from the lowest: compound 4; then compounds 1 and 2 (each within the scatter of the next); then compound 3.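

In this assay, the chloro on the aromatic carbon para to a large group turns out not to be needed for a low number, since replacing it with hydrogen gives a 2.5-fold lower number from compound 1 to compound 4 (0.41 log units; beyond the scatter). For the compounds shown here, this is the first look at this end of the molecule, and it shows that the loss of one heavy atom, with no ring, no hydrogen-bond donor or acceptor and no net charge involved, is enough to move the number beyond the usual scatter, here in favour of the plain phenoxy group over the 4-chlorophenoxy group. Nothing among the available data says why the number falls on this change.

The compounds shown leave open whether this result is specific to chloro or whether any group at this place raises the number, a question that fluoro, methyl or methoxy on the same aromatic carbon would address. They also leave open whether the hydrogen keeps its advantage with a longer chain between the phenoxy group and the nitrogen, or with the nitro group replaced by a nitrile.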